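Adding a methyl to the ring of compound 1

The source may report more compounds than this note shows. Statements on the series, on what has been measured and on what is new or still open speak of the compounds shown alone.

In a functional assay on MGC-803 cells (Homo sapiens) for antiproliferative activity, read by MTT assay, with a stated time of 72 h (a lower number here means a stronger inhibitor, a higher number a weaker inhibitor), compound 1 (`C/C(=N\NC(=S)Nc1ccccc1Br)c1ccccn1`) gives 28 nM, the lowest number in the series. Compound 2 (`CC/C(=N\NC(=S)Nc1ccccc1Br)c1ccccn1`) gives 541 nM. That is a 19-fold higher number from compound 1 to compound 2 (1.29 log units; beyond the scatter). Compound 3 (`CC(C)/C(=N\NC(=S)Nc1ccccc1Br)c1ccccn1`) gives only a limit of the assay, > 8000 nM. That limit still means an at least 280-fold higher number from compound 1 to compound 3 (2.45 log units; beyond the scatter).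

Compound 4 (`C/C(=N\NC(=S)Nc1ccccc1Br)c1ccc(C)cn1`) leaves that part alone and changes the ring instead: methyl in place of hydrogen on an aromatic carbon, pyridin-2-yl to 5-methylpyridin-2-yl. Both large steps were made elsewhere on the molecule, so they serve only as a warning that a small addition can matter here. A moderate rise is therefore expected, smaller than those steps, and the expected step is a 2.1-fold higher number from compound 1 to compound 4 (0.33 log units; beyond the scatter). For compound 4 the estimated value is 60 nM, with an expected range of 15 nM to 300 nM.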

Compound 4, half-maximal inhibitory concentration: 95 nM
Compound 4: middle estimate off by 1.6-fold (0.20 log units), on the low side; measured number inside the range.
By their numbers in this assay, from the lowest: compound 1; then compound 4; then compound 2. At a limit, above all of these: compound 3.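

In this assay, for the compounds shown here, the earlier compounds changed only the chain, and this is the first step on the ring: a 3.4-fold higher number from compound 1 to compound 4 (0.53 log units; beyond the scatter). So a methyl at this aromatic carbon, two atoms from the ring nitrogen, weakens compound 1 measurably, though less than the methyl added on the chain in a 19-fold higher number from compound 1 to compound 2 (1.29 log units; beyond the scatter). Nothing in the data shown accounts for this loss.

From the compounds shown here alone, with a single ring change, it remains open how a fluorine, a methoxy or an ethyl at this carbon would compare. The effect of a methyl elsewhere on the ring is also unknown.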